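Para substituent scan on the anilino quinone series

A few compounds are considered here, and "the series" means these few. Any claim that something is new, unique, unknown or untested is made for them only; others in the source may bear on it.

Measured so far:
compound 1 `CCCc1ccc(NC2=CC(=O)c3c(nc4n3[C@H]3OC[C@@H](O)[C@H]3OC4)C2=O)cc1` — 1920 nM
compound 2 `O=C1C(Nc2ccccc2)=CC(=O)c2c1nc1n2[C@H]2OC[C@@H](O)[C@H]2OC1` — 1830 nM
compound 3 `O=C1C(Nc2ccc(C(F)(F)F)cc2)=CC(=O)c2c1nc1n2[C@H]2OC[C@@H](O)[C@H]2OC1` — 1860 nM

Three compounds share one core and differ only in the group on an aromatic carbon of the anilino ring. In a functional assay on MGC-803 cells (Homo sapiens) for inhibition, read by sulforhodamine B assay (a higher number here means a weaker inhibitor, a lower number a stronger inhibitor), compound 3 gives 1860 nM, the second highest of the three numbers; compound 2 gives 1830 nM and compound 1 gives 1920 nM, and all three lie within the scatter of one another. The steps are a 1.0-fold lower number from compound 1 to compound 2 (0.02 log units; within the scatter), a 1.0-fold lower number from compound 1 to compound 3 (0.01 log units; within the scatter) and a 1.0-fold higher number from compound 2 to compound 3 (0.01 log units; within the scatter): swapping propyl, hydrogen and trifluoromethyl at this position leaves this assay unchanged.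

Compound 4 `O=C1C(Nc2ccc(I)cc2)=CC(=O)c2c1nc1n2[C@H]2OC[C@@H](O)[C@H]2OC1` continues the same scan: iodo in place of trifluoromethyl on an aromatic carbon. Within the data shown here, the steps that bear on it are the three above, each of them flat. The group at this aromatic carbon has so far shown no effect, whether small or large, so for compound 4 no step beyond the scatter is expected in either direction.

Compound 4 is therefore estimated at 1850 nM in this assay, with a range of 900 nM to 3800 nM, which means an expected step of a 1.0-fold lower number from compound 3 to compound 4 (0.00 log units; within the scatter).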

Compound 4, half-maximal inhibitory concentration: 2150 nM
Beside the measured number, compound 4's estimate is 1.2-fold (0.07 log units) below it; the range from low to high includes it.
By their numbers in this assay, from the lowest: compounds 2, 3, 1 and 4 (each within the scatter of the next).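

In this assay the iodo group fits the flat picture at this aromatic carbon, with a 1.2-fold higher number from compound 3 to compound 4 (0.06 log units; within the scatter) against trifluoromethyl, a 1.2-fold higher number from compound 2 to compound 4 (0.07 log units; within the scatter) against hydrogen and a 1.1-fold higher number from compound 1 to compound 4 (0.05 log units; within the scatter) against propyl. Even the exchange of the multi-atom trifluoromethyl for a single iodine atom leaves the number within the scatter, so hydrogen, propyl, trifluoromethyl and iodo cannot be told apart at this position in this assay and the flat result now extends to a halogen atom on the ring. No measurement at hand speaks to what lies behind this lack of response.

On these data alone, whether an amine, a carboxylic acid or a longer chain at this aromatic carbon would also leave the number flat remains open, as does the outcome of moving any of these groups to another carbon of the anilino ring. The compounds shown also leave open whether changes to the shared core would move the number, and whether the same flat response holds in other cell lines.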